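Swapping the cyanoguanidine for a thiourea on the shared core

A few compounds are considered here, and "the series" means these few. Any claim that something is new, unique, unknown or untested is made for them only; others in the source may bear on it.

Compound 1 `CC/N=C(/NC#N)NCCCCn1nc(-c2ccccc2)ccc1=O` is tested in a functional assay on the whole organism with Rattus norvegicus as the target (on this read-out higher numbers stand for an effect only at larger amounts of compound and lower numbers for an effect already at smaller amounts), where it gives 60.7 mg/kg. Compound 2 `C/N=C(\S)NCCCCCn1nc(-c2ccccc2)ccc1=O` gives 42.1 mg/kg and compound 3 `CC/N=C(/NC#N)NCCCn1nc(-c2ccccc2)ccc1=O` gives 88.5 mg/kg; compound 1 sits within the usual scatter of both, so the three cannot be ranked. Compound 4 `C=CCNC(=S)NCCCCn1nc(-c2ccccc2)ccc1=O` differs from compound 1 in one place: a group of 6 heavy atoms (4 carbon, 1 nitrogen, 1 sulfur; no ring) in place of a group of 7 heavy atoms (4 carbon, 3 nitrogen; no ring), on an amine nitrogen. Among the measured compounds shown here, the closest precedent is the exchange of a nitrogen-rich group for a sulfur-bearing one, which gave a 1.4-fold lower number from compound 1 to compound 2 (0.16 log units; within the scatter); the shortening of the chain gave a 2.1-fold higher number from compound 2 to compound 3 (0.32 log units; beyond the scatter) but does not apply here. A shift within the scatter is therefore expected in this assay, a 1.2-fold lower number from compound 1 to compound 4 (0.08 log units; within the scatter). Compound 4 is estimated at 50 mg/kg, with a likely range from 25 mg/kg to 100 mg/kg.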

Compound 4, dose for half-maximal effect: 78.6 mg/kg
Compound 4: the middle estimate sits 1.6-fold (0.20 log units) below what was measured, within the range that was stated.
By their numbers in this assay, from the lowest: compounds 2, 1, 4 and 3 (each within the scatter of the next, the first and the last beyond it).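

On the amine nitrogen, exchanging the group carrying the nitrile for a thiourea group leaves the result in this assay within the scatter (a 1.3-fold higher number from compound 1 to compound 4 (0.11 log units; within the scatter)). The other two comparisons also stay within it (a 1.1-fold lower number from compound 3 to compound 4 (0.05 log units; within the scatter); a 1.9-fold higher number from compound 2 to compound 4 (0.27 log units; within the scatter)), so compound 4 cannot be separated from any earlier compound, even though compound 2 and compound 3 differ beyond the scatter. Nothing available gives a reason for these results.

As far as these compounds go, whether a urea or a plain amine at this place would move the dose beyond the scatter stays open.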